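Removing the Benzyl Group from Compound 3

The source may report more compounds than this note shows. Statements on the series, on what has been measured and on what is new or still open speak of the compounds shown alone.

Measured compounds and values:
Compound 1 `Cc1ccc(S(=O)(=O)/N=C(/CCNC2=CC(=O)c3ccccc3C2=O)Nc2ccc(F)cc2)cc1`: 9330 nM
Compound 2 `COc1ccc(N/C(CCNC2=CC(=O)c3ccccc3C2=O)=N\S(=O)(=O)c2ccc(C)cc2)c(OC)c1`: 126000 nM
Compound 3 `Cc1ccc(S(=O)(=O)/N=C(/CCNC2=CC(=O)c3ccccc3C2=O)NCc2ccccc2)cc1`: 7410 nM

All three share one core and were tested in a functional assay on A549 cells (Homo sapiens) for cytotoxicity, read by MTT assay, with a stated time of 48 h; a lower number here means a stronger inhibitor, a higher number a weaker inhibitor. Compound 3 gives the lowest of the three numbers, but the step of a 1.3-fold lower number from compound 1 to compound 3 (0.10 log units; within the scatter) is small, so compounds 1 and 3 cannot be told apart on these data. The step of a 17-fold lower number from compound 2 to compound 3 (1.23 log units; beyond the scatter) is large, and so is a 14-fold higher number from compound 1 to compound 2 (1.13 log units; beyond the scatter), which shows that what sits on this amine nitrogen can shift the number substantially.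

Compound 4 `Cc1ccc(S(=O)(=O)/N=C(\N)CCNC2=CC(=O)c3ccccc3C2=O)cc1` differs from compound 3 by hydrogen in place of benzyl on an amine nitrogen. Among the compounds with values here, no measured step removes the group from this nitrogen entirely; the measured steps only exchange one carbon-based group for another. Among them, swapping an aromatic ring for a benzyl left the number essentially unchanged, while a different aromatic ring raised it sharply. Stripping the nitrogen bare is a larger departure than any of these, so the expectation carries wide uncertainty. A modest rise in the number is expected for compound 4, the step being a 2.2-fold higher number from compound 3 to compound 4 (0.33 log units; beyond the scatter). Compound 4 is therefore estimated at 16000 nM, within a range from 4000 nM to 65000 nM.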

Compound 4, half-maximal inhibitory concentration: 26600 nM
Estimate against measurement, compound 4: 1.7-fold (0.22 log units) below; low and high end bracket the measured number.
By their numbers in this assay, from the lowest: compounds 3 and 1 (each within the scatter of the next); then compound 4; then compound 2.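

In this assay, within the data shown here, this is the first compound with no carbon group on this amine nitrogen, and the bare amino group does not give the lowest number: taking benzyl away gives a 3.6-fold higher number from compound 3 to compound 4 (0.56 log units; beyond the scatter) and replacing 4-fluorophenyl with hydrogen gives a 2.9-fold higher number from compound 1 to compound 4 (0.45 log units; beyond the scatter). Hydrogen does not give the highest number either, since replacing 2,4-dimethoxyphenyl with hydrogen gives a 4.7-fold lower number from compound 2 to compound 4 (0.68 log units; beyond the scatter) and so places the unsubstituted compound between the substituted ones. The bare nitrogen therefore serves as a reference point that the earlier exchanges could not supply: benzyl and 4-fluorophenyl, which cannot be told apart from each other, both give lower numbers than hydrogen, while 2,4-dimethoxyphenyl gives a higher one, so a group here can move the number in either direction depending on which group it is.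

The compounds shown leave open whether a small methyl group or a longer chain such as phenethyl would fall nearer to benzyl or to hydrogen, and whether a single methoxy group on the phenyl ring would be enough to raise the number. Nothing measured alongside these values accounts for the opposite shifts.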